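The source may hold more compounds than are shown below. What is called first, only, known or untested is meant among the compounds shown, and "the series" means these compounds.

Measured in a functional assay on HT-29 cells (Homo sapiens) for antiproliferative activity, read by MTT assay, with a stated time of 72 h; a lower number here means a stronger inhibitor of growth, a higher number a weaker inhibitor of growth:
Compound 1 `CC(C)Cn1c(SCc2ccccc2)nc(N)cc1=O`: only the assay limit, > 100000 nM.
Compound 2 `CC(=O)Nc1cc(=O)n(Cc2ccccc2)c(SCc2ccccc2)n1`: 79300 nM.
Compound 3 `Cc1ccc2nc(-c3ccc(N)cc3)cn2c1`: 82900 nM.

Compound 1 sits at the limit of > 100000 nM in this assay, at which 1 of the 3 values shown sits, so it contributes a limit rather than a number. Of the two numbers, compound 3 gives the higher, yet the gap to compound 2 lies within the scatter, so the two are not separated. Compound 4 `Cc1ccc2nc(-c3ccc(NCc4ccccc4)cc3)cn2c1` differs from compound 3 by benzyl in place of hydrogen on a nitrogen on an aromatic ring. For the measured compounds named here, no measured pair shows this change; compounds 1 and 2 carry benzyl groups on different cores, and both are weak. Across this step the expected change in this assay is none beyond the scatter, a 1.2-fold lower number from compound 3 to compound 4 (0.07 log units; within the scatter). Compound 4 is accordingly estimated at 70000 nM, with a range from 20000 nM to 100000 nM.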

Compound 4, concentration for 50% growth inhibition: 8800 nM
Beside the measured number, compound 4's estimate is 8.0-fold (0.90 log units) above it, outside the stated range (below it).
By their numbers in this assay, from the lowest: compound 4; then compounds 2 and 3 (each within the scatter of the next). At a limit, above all of these: compound 1.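

In this assay, for the compounds shown here, amino to benzylamino on a nitrogen on an aromatic ring gives a 9.4-fold lower number from compound 3 to compound 4 (0.97 log units; beyond the scatter) as the only step available. Going by these compounds alone, the earlier compounds offered no step, so this is the first sign that the series responds to a change at this nitrogen. Nothing measured here gives a cause for the step.

On these data alone, it remains open whether the benzyl ring itself matters or any group on this nitrogen would do. Methyl, a longer alkyl chain or cyclohexylmethyl at this place would separate these readings.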